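This account rests on a few compounds, and the source may have more. Where it says the series, first, only, none or still open, it means among the compounds named here.

Measured compounds:
Compound 1, `Cn1c(=O)c(=O)n(C2CCCC2)c2nc(N/N=C/c3ccc(O)cc3)ncc21`: in a functional assay on PC-3 cells (Homo sapiens) for antiproliferative activity, read by MTT assay (a lower number here means a stronger inhibitor, a higher number a weaker inhibitor), compound 1 gives > 100000 nM, which is a limit of the assay and not a number.
Compound 2, `Cn1c(=O)c(=O)n(C2CCCC2)c2nc(N/N=C/c3cccc(Cl)c3Cl)ncc21`: in this assay compound 2 gives 17200 nM.

Within the data shown here, compound 2 thus stands as the only compound with a number in this assay; the remaining value sits at the limit of > 100000 nM in this assay, at which 1 of the 2 values shown sits. Among the measured compounds shown here, the one measured step, an at least 5.8-fold lower number from compound 1 to compound 2 (0.76 log units; beyond the scatter), came with 2,3-dichlorophenyl in place of 4-hydroxyphenyl on a carbon with a double bond to nitrogen, and it shows that the group on that carbon can move the number by at least a modest amount.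

Compound 3, `Cc1ccc(/C=N/Nc2ncc3c(n2)n(C2CCCC2)c(=O)c(=O)n3C)cc1C`, differs from compound 2 by 3,4-dimethylphenyl in place of 2,3-dichlorophenyl on a carbon with a double bond to nitrogen. The measured step exchanged a group with a hydrogen-bond donor and acceptor for one with none; the present change swaps one group with neither donor nor acceptor for another of the same kind, so it bears only loosely on this case. Compound 3 is therefore expected to show a step of a 1.7-fold higher number from compound 2 to compound 3 (0.24 log units; within the scatter), within the scatter. Compound 3 is estimated at 30000 nM, between 8000 nM and 120000 nM.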

Compound 3, half-maximal inhibitory concentration: 39000 nM
Estimate against measurement, compound 3: 1.3-fold (0.11 log units) below, within the range that was stated.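

In this assay, the step of this result, a 2.3-fold higher number from compound 2 to compound 3 (0.36 log units; beyond the scatter), shows that the number still moves at this position when neither the leaving group nor the entering group has a hydrogen-bond donor or acceptor, and when both have the same number of heavy atoms. The change replaces the chlorines with methyl groups and also alters where they sit on the phenyl ring, so the step cannot be assigned to either difference alone. With 3,4-dimethylphenyl in place of 4-hydroxyphenyl there is also an at least 2.5-fold lower number from compound 1 to compound 3 (0.40 log units; beyond the scatter), so both groups without a donor or acceptor give a lower number than 4-hydroxyphenyl, although this step is only a bound: the limit of > 100000 nM in this assay, at which 1 of the 3 values shown sits.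

Going by these compounds, whether 3,4-dichlorophenyl or 2,3-dimethylphenyl would separate the kind of substituent from its place remains open, as does how a phenyl ring carrying an amine or a carboxylic acid would read in this assay. All three compounds share one core, so nothing here tells whether these steps would hold on another.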